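Sulfonamide aryl swap in a cinnamoyl benzimidazole series

A few compounds are considered here, and "the series" means these few. Any claim that something is new, unique, unknown or untested is made for them only; others in the source may bear on it.

Measured so far:
- compound 1 `O=C(/C=C/c1cccc(NS(=O)(=O)c2cccc(Cl)c2)c1)c1nc2ccccc2[nH]1`: 4160 nM
- compound 2 `O=C(/C=C/c1cccc(NS(=O)(=O)c2cc(Cl)cc(Cl)c2)c1)c1nc2ccccc2[nH]1`: 20000 nM

The two compounds differ only on the sulfonyl aryl ring. In a functional assay on MCF7 cells (Homo sapiens) for antiproliferative activity, read by MTT assay, with a stated time of 48 h (a lower number here means a stronger inhibitor, a higher number a weaker inhibitor), compound 1 gives 4160 nM, and compound 2 gives 20000 nM. Among the measured compounds shown here, the one step recorded is a 4.8-fold higher number from compound 1 to compound 2 (0.68 log units; beyond the scatter); compound 2 therefore has the highest number of the two, with compound 1 as its only neighbour.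

Compound 3 `Cc1cc(C)cc(S(=O)(=O)Nc2cccc(/C=C/C(=O)c3nc4ccccc4[nH]3)c2)c1` is the next member, not yet measured in this assay. Relative to compound 2 the change is 3,5-dimethylphenyl in place of 3,5-dichlorophenyl on a sulfonyl sulfur. For the measured compounds named here, no measured step covers a halogen-to-methyl exchange on this ring, so the only bearing evidence is a 4.8-fold higher number from compound 1 to compound 2 (0.68 log units; beyond the scatter), which shows that the second chloro raised the number by a modest but real amount. Going by the values given here, removing both chlorines in favour of methyls has no direct precedent here; the expectation is a step in the opposite direction, of a size about like that of the recorded step, but with wide uncertainty. The estimated change is a 2.5-fold lower number from compound 2 to compound 3 (0.40 log units; beyond the scatter). For compound 3 the expected value in this assay is 8000 nM, with a range of 2500 nM to 30000 nM.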

Compound 3, half-maximal inhibitory concentration: 4570 nM
For compound 3 the middle estimate is 1.8-fold (0.24 log units) above the measured one, within the range that was stated.
By their numbers in this assay, from the lowest: compounds 1 and 3 (each within the scatter of the next); then compound 2.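

In this assay the sulfonyl aryl position responds to which groups the ring carries and not merely to how many: 3,5-dimethylphenyl in place of 3,5-dichlorophenyl on a sulfonyl sulfur gives a 4.4-fold lower number from compound 2 to compound 3 (0.64 log units; beyond the scatter) and so reverses a step of about the same size as the one seen on adding the second chloro. Against 3-chlorophenyl, the same 3,5-dimethylphenyl group gives a 1.1-fold higher number from compound 1 to compound 3 (0.04 log units; within the scatter) and so leaves compound 1 and compound 3 indistinguishable, which means that two substituents on this ring do not by themselves set compound 2 apart. Nothing available explains the difference between 3,5-dichlorophenyl and 3,5-dimethylphenyl at this position.

Where an unsubstituted phenyl or a 3-methylphenyl would fall relative to compound 1 and compound 3 remains open, so the single methyl cannot yet be set against the single chloro. As far as these compounds go, it is also open whether a methoxy, an amine or a carboxylic acid on this ring would stay with compound 1 and compound 3 or move toward compound 2.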